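The source may hold more compounds than are shown below. What is called first, only, known or untested is meant among the compounds shown, and "the series" means these compounds.

Measured so far in a functional assay on the whole organism with Rattus norvegicus as the target; on this read-out lower numbers stand for an effect already at smaller amounts and higher numbers for an effect only at larger amounts of compound:
- compound 1, `CN(C)/C(=N/CCCCn1nc(-c2ccccc2)ccc1=O)NC#N`: 52.9 mg/kg
- compound 2, `C/N=C(\S)NCCCCCn1nc(-c2ccccc2)ccc1=O`: 42.1 mg/kg
- compound 3, `O=c1ccc(-c2ccccc2)nn1CCCCNC(=S)Nc1ccccc1`: a limit, > 100 mg/kg

Compound 1 holds the highest of the two numbers shown, with compound 2 nearest; the step of a 1.3-fold lower number from compound 1 to compound 2 (0.10 log units; within the scatter) is within the scatter. For compound 3 the result is only a limit of this assay, (the limit of > 100 mg/kg in this assay, at which 1 of the 3 values shown sits), not a number.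

Compound 4, `C=CCNC(=S)NCCCCn1nc(-c2ccccc2)ccc1=O`, is not yet measured. It differs from compound 1 in one place: a group of 7 heavy atoms (4 carbon, 2 nitrogen, 1 sulfur; no ring) in place of a group of 8 heavy atoms (4 carbon, 4 nitrogen; no ring), on a saturated chain carbon, four bonds along the chain from an aromatic nitrogen. Among the compounds with values here, only one measured step, from compound 1 to compound 2, bears on such a replacement, and it stayed within the scatter; that step also lengthened the chain and gave a different end group, so it is an imperfect guide. Compound 3, which carries a thiourea too but with a phenyl end, gives only a limit. On this basis no step beyond the scatter is expected for compound 4, and a 1.0-fold higher number from compound 1 to compound 4 (0.02 log units; within the scatter) is the estimated change. The expected value for compound 4 is 55 mg/kg, within 25 mg/kg to 120 mg/kg.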

Compound 4, dose for half-maximal effect: 78.6 mg/kg
Compound 4: the middle estimate sits 1.4-fold (0.16 log units) below what was measured; the range from low to high includes it.
By their numbers in this assay, from the lowest: compounds 2, 1 and 4 (each within the scatter of the next). At a limit, above all of these: compound 3.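

In this assay, the group of 7 heavy atoms with sulfur in place of the group of 8 heavy atoms, on the same saturated chain carbon, gives a 1.5-fold higher number from compound 1 to compound 4 (0.17 log units; within the scatter) and so shows that this replacement alone, without the chain change of compound 2, produces no step beyond the scatter. Among the sulfur-bearing groups, the comparison reads a 1.9-fold higher number from compound 2 to compound 4 (0.27 log units; within the scatter) and shows no separation either. Allyl in place of phenyl on an amide-type nitrogen gives an at least 1.2-fold lower number from compound 3 to compound 4 (0.10 log units; that floor lies within the scatter) and says little about the size of this change, since compound 3 gives only a limit: the limit of > 100 mg/kg in this assay, at which 1 of the 4 values shown sits.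

Whether the end group matters at this position remains open, with every number shown within the scatter of the next. Also open, as far as these compounds go, is how a carboxylic acid, a dimethylamino end or a longer chain carrying the allyl thiourea would compare.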